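Removing a bromo group from a weak sulfone compound

A few compounds are considered here, and "the series" means these few. Any claim that something is new, unique, unknown or untested is made for them only; others in the source may bear on it.

Measured so far in a functional assay on DU-145 cells (Homo sapiens) for cytotoxicity, read by MTT assay; a lower number here means a stronger inhibitor, a higher number a weaker inhibitor:
compound 1 `CC(O)(CSc1ccc(F)cc1)c1nc(-c2ccc(Cl)cc2)no1` gives 36300 nM;
compound 2 `CC(O)(CS(=O)(=O)c1ccc(Br)cc1)c1nc(-c2ccccc2)no1` gives > 100000 nM;
compound 3 `CC(O)(CSc1ccccc1)c1nc(-c2ccc(F)c(Cl)c2)no1` gives 5500 nM.

All three share the same core, with an aryl sulfide or sulfone on one side and a substituted or plain phenyl on the other. Compound 1 and compound 3, both sulfides, give numbers, and the number of compound 3 is the smaller of the two. For compound 2 the value is not a number but a limit of this assay, as stated in the limit of > 100000 nM in this assay, at which 1 of the 3 values shown sits; nothing finer than that is known for it. Within the data shown here, compound 2 is therefore the one compound here without a measured number, and it sits at the edge of what this assay can report.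

The next compound, compound 4, is `CC(O)(CS(=O)(=O)c1ccccc1)c1nc(-c2ccccc2)no1`. It differs from compound 2 in one place: hydrogen in place of bromo on an aromatic carbon. The para position is the one the difference occupies, and the rest of the molecule is unchanged. Among the measured compounds shown here, no step between measured compounds here describes what such a change does, so the expectation must lean on the limit of compound 2 alone. Starting from a limit, a step in either direction cannot be read off, and a change of this kind is expected to move compound 4 by little, if anything, beyond the scatter, as the step of a number no higher from compound 2 to compound 4 (the limit leaves the size open) expresses. Compound 4 is thus estimated at 100000 nM, with a range from 30000 nM to 300000 nM, and it may well again be reported only as a limit.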

Compound 4, half-maximal inhibitory concentration: > 100000 nM
Compound 4 was reported as a limit; the forecaster's own chance of this, stated with the estimate: 60%; the middle value sits exactly at the limit.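

No step can be read between compound 2 and compound 4, because each is reported only as a limit, not as a number: the limit of > 100000 nM in this assay, at which 2 of the 4 values shown sit.

Still open, from the compounds shown here alone, is whether going from 4-bromophenyl to phenyl changes anything in this assay, and how a sulfone and a sulfide compare when the rest of the molecule is the same.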